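Methyl on the ring of two sulfonamide amides

The source may hold more compounds than are shown below. What is called first, only, known or untested is meant among the compounds shown, and "the series" means these compounds.

Measured so far:
Compound 1, `CCN1CCCC1CNC(=O)c1cc(NS(=O)(=O)N(C)C)ccc1OC`, in a functional assay on the whole organism for inhibition, with Mus musculus as the target (a higher number here means that more compound is needed for the effect, a lower number that less compound is needed), gives > 50 mg/kg, which is a limit of the assay.
Compound 2, `CCN1CCCC1CNC(=O)c1cc(NS(=O)(=O)N(C)C)c(C)cc1OC`, in this assay gives 13.3 mg/kg.
Compound 3, `CCN1CCCC1CNC(=O)c1cc(NS(C)(=O)=O)ccc1OC`, in this assay gives > 50 mg/kg, which is a limit of the assay.

Among the measured compounds shown here, the one numbered step is an at least 3.7-fold lower number from compound 1 to compound 2 (0.57 log units; beyond the scatter), made by methyl in place of hydrogen on an aromatic carbon. The other measured pair gives a step that the two limits leave unreadable from compound 1 to compound 3, the change being (methyl in place of dimethylamino on a sulfonyl sulfur); that is also how the core of compound 3 differs from the core of compound 1. Both of these compounds sit at the limit of > 50 mg/kg in this assay, at which 2 of the 3 values shown sit, so what the sulfonyl change did cannot be read.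

Compound 4, `CCN1CCCC1CNC(=O)c1cc(NS(C)(=O)=O)c(C)cc1OC`, is not yet measured. It differs from compound 3 by methyl in place of hydrogen on an aromatic carbon. This is the same kind of change as from compound 1 to compound 2, not the same one: there the entering methyl stands ortho to a (dimethylsulfamoyl)amino group (7 heavy atoms), here ortho to a methanesulfonamido group (5 heavy atoms). The expectation for compound 4 rests on compound 1 to compound 2 alone, where the methyl gave an at least 3.7-fold lower number from compound 1 to compound 2 (0.57 log units; beyond the scatter) from a starting limit. The step is expected to be an at least 2.5-fold lower number from compound 3 to compound 4 (0.39 log units; beyond the scatter), though the start from a limit leaves its size open. Compound 4 is therefore estimated at 20 mg/kg in this assay, within 8 mg/kg to 60 mg/kg, with a real chance that only a limit is again reported.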

Compound 4, dose for half-maximal effect: 35.6 mg/kg
Compound 4: the middle estimate sits 1.8-fold (0.25 log units) below what was measured, within the range that was stated.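

In this assay, methyl in place of hydrogen on the aromatic carbon gives an at least 1.4-fold lower number from compound 3 to compound 4 (0.14 log units; that floor lies within the scatter), so the lower number seen on the core of compound 1 is seen again on the core of compound 3, though the floor of this second step does not clear the scatter. This supports the same direction of change on these two cores, but not a shared size, and two cores are too few to support a rule for the series: the same change on two cores in this assay, an at least 3.7-fold lower number (0.57 log units; beyond the scatter) from compound 1 to compound 2 and an at least 1.4-fold lower number (0.14 log units; that floor lies within the scatter) from compound 3 to compound 4; the limit leaves it open whether they differ. With the ring methyl present, methyl in place of dimethylamino on the sulfonyl sulfur gives a 2.7-fold higher number from compound 2 to compound 4 (0.43 log units; beyond the scatter), which shows that the sulfonyl group matters on this methylated core but not that it matters equally on the core without the ring methyl.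

The true size of each methyl step and the step between compound 1 and compound 3 cannot be read, because both starting compounds carry only a limit: the limit of > 50 mg/kg in this assay, at which 2 of the 4 values shown sit. From the compounds shown here alone, it also remains open whether the methyl step carries over when ethyl or a longer chain stands on the sulfonyl sulfur, and whether chlorine on the same aromatic carbon would give a step like that of methyl.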